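The source may hold more compounds than are shown below. What is called first, only, known or untested is meant among the compounds shown, and "the series" means these compounds.

Compound 3 `CCn1cc(C(=O)N2N=C(c3cc4ccccc4o3)CC2c2ccccc2Cl)c(=O)c2ccc(C)nc21` carries a 2-chlorophenyl group on the saturated ring of the shared core. In an ADME assay on Vero cells (Chlorocebus sabaeus) for cytotoxicity, read by MTT assay, with a stated time of 72 h (on this read-out lower numbers stand for stronger inhibition and higher numbers for weaker inhibition), compound 3 gives > 178000 nM, which is a limit of the assay rather than a number. Compound 1 `CCn1cc(C(=O)N2N=C(c3cc4ccccc4o3)CC2c2ccccc2O)c(=O)c2ccc(C)nc21` gives > 157000 nM, also a limit. Compound 2 `CCn1cc(C(=O)N2N=C(c3cc4ccccc4o3)CC2c2ccc(N(C)C)cc2)c(=O)c2ccc(C)nc21` gives > 206000 nM, a limit as well. The steps a step that the two limits leave unreadable from compound 1 to compound 2, a step that the two limits leave unreadable from compound 1 to compound 3 and a step that the two limits leave unreadable from compound 2 to compound 3 are therefore not readable in size or direction. Compound 4 `CCn1cc(C(=O)N2N=C(c3cc4ccccc4o3)CC2c2ccccc2[N+](=O)[O-])c(=O)c2ccc(C)nc21` differs from compound 3 by nitro in place of chloro on an aromatic carbon. For the measured compounds named here, no measured step bears on this change, and with all three values at limits no direction can be drawn. Compound 4 is expected to remain at the limit, estimated at 200000 nM within 100000 nM to 400000 nM. The expected step is a step that the limit leaves unreadable from compound 3 to compound 4.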

Compound 4, half-maximal inhibitory concentration: > 85400 nM
Compound 4: a limit, no number (the forecaster's own chance of this, stated with the estimate: 85%); the middle value is on the limit's open side.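

For the compounds shown here, compound 4, like compound 1, compound 2 and compound 3, is recorded only as a limit, so no step to compound 4 can be read. The compounds shown leave open whether changing the aryl group on the saturated ring alters the result in this assay at all.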